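Amide-to-aryl swap on the shared core: compound 4 outlook

The source may hold more compounds than are shown below. What is called first, only, known or untested is meant among the compounds shown, and "the series" means these compounds.

Measured compounds:
- compound 1 `COc1cc(Cl)cc(-c2nn(-c3cccc(NC(=O)c4ccc(Cl)c(Cl)c4)c3)cc2-c2ccncc2)c1`: 46.4%
- compound 2 `COc1cc(Cl)cc(-c2nn(-c3cccc(NC(=O)Nc4ccc(Cl)c(C(F)(F)F)c4)c3)cc2-c2ccncc2)c1`: 8.93%
- compound 3 `COc1cc(Cl)cc(-c2nn(-c3cccc(NC(=O)Nc4cc(C(F)(F)F)cc(C(F)(F)F)c4)c3)cc2-c2ccncc2)c1`: 6.4%

In a functional assay on K562 cells (Homo sapiens) for inhibition, read by sulforhodamine B assay, with a stated time of 48 h, tested at 10 uM (on this read-out lower numbers stand for a stronger effect and higher numbers for a weaker effect at the one concentration tested), compound 1 gives the highest of the three numbers, so the weakest effect among the measured compounds; compound 2 and compound 3 both lie beyond the scatter below it. For the measured compounds named here, the one step of a single change, a number 37.5 percentage points lower from compound 1 to compound 2 (beyond the scatter), replaces the aryl on the carbonyl carbon and at the same time turns the amide into a urea, so it does not isolate the aryl exchange alone.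

Compound 4 `COc1cc(Cl)cc(-c2nn(-c3cccc(NC(=O)c4cccc(C(F)(F)F)c4)c3)cc2-c2ccncc2)c1` keeps the amide of compound 1 and differs only in the aryl: 3-(trifluoromethyl)phenyl in place of 3,4-dichlorophenyl on a carbonyl carbon. Going by the values given here, no measured pair shows this change with the amide held fixed, so the step from compound 1 to compound 2 bears on it only loosely, and its size is not taken as a guide. With one chlorine removed and the trifluoromethyl kept, compound 4 is expected to stay near compound 1, the step of a number 5.6 percentage points higher from compound 1 to compound 4 (within the scatter) being expected to lie within or close to the scatter. For compound 4 the estimate in this assay is 52%, with a range from 32% to 75%.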

Compound 4, a percentage reported as activity, at one concentration (the size of the read-out at that concentration, not a potency): 26%
Estimate against measurement, compound 4: 26 percentage points above; the whole stated range lies above it.
By their numbers in this assay, from the lowest: compounds 3 and 2 (each within the scatter of the next); then compound 4; then compound 1.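

In this assay, the aryl on the carbonyl carbon can now be read with the amide held fixed: a number 20.4 percentage points lower from compound 1 to compound 4 (beyond the scatter), a step beyond the scatter with no urea involved, so this position responds to the aryl exchange alone. The second step, a number 17.1 percentage points higher from compound 2 to compound 4 (beyond the scatter), combines loss of the urea nitrogen with loss of the chlorine, and shows that the amide with 3-(trifluoromethyl)phenyl still gives a weaker effect than the urea with its 4-chloro-3-(trifluoromethyl)phenyl group, without saying which of the two changes matters. Nothing measured here accounts for either step.

For the compounds shown here, open is how much of the difference belongs to the urea itself, since no pair holds the aryl fixed while exchanging amide for urea. The compounds shown also give no reading for a carboxylic acid or a dimethylamine on the aryl, or for a longer chain on the carbonyl carbon in place of the aryl.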